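Aryl amide series: methyl to ethoxycarbonyl

The source may report more compounds than this note shows. Statements on the series, on what has been measured and on what is new or still open speak of the compounds shown alone.

Measured so far in an ADME assay on MT4 cells (Homo sapiens) for cytotoxicity, read by MTT assay (a lower number here means that less compound is tolerated, a higher number that more compound is tolerated), for three compounds:
- compound 1 `O=C(CSc1nncnc1-c1cccc2ccccc12)Nc1ccccc1[N+](=O)[O-]` gives 142000 nM
- compound 2 `Cc1ccc(NC(=O)CSc2nncnc2-c2cccc3ccccc23)c(Br)c1` gives 166000 nM
- compound 3 `O=C(CSc1nncnc1-c1cccc2ccccc12)Nc1cccnc1Cl` gives 44000 nM

Compound 2 shares the top of this short range with its nearest neighbour, and the gap, a 1.2-fold higher number from compound 1 to compound 2 (0.07 log units; within the scatter), stays within the scatter. The steps of a 3.8-fold lower number from compound 2 to compound 3 (0.58 log units; beyond the scatter) and a 3.2-fold lower number from compound 1 to compound 3 (0.51 log units; beyond the scatter) are the only ones beyond the scatter, and both are modest.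

Next is compound 4 `CCOC(=O)c1ccc(NC(=O)CSc2nncnc2-c2cccc3ccccc23)c(Br)c1`, which carries ethoxycarbonyl in place of methyl on an aromatic carbon and keeps the rest of compound 2. Within the data shown here, no measured step makes this exact change. All three replace the whole aryl group on the amide nitrogen, so they give only a rough idea of how far this assay moves in this series. Compound 2 stands at 166000 nM and the steps beyond the scatter lead down from it, so a small downward step is expected, no larger than those modest ones. The estimated change is a 1.7-fold lower number from compound 2 to compound 4 (0.22 log units; within the scatter) and may not clear the scatter. For compound 4 the expected value is 100000 nM with an estimated range from 40000 nM to 230000 nM for now.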

Compound 4, half-maximal cytotoxic concentration: 105000 nM
The estimate for compound 4 lay 1.1-fold (0.02 log units) below the measured number; low and high end bracket the measured number.
By their numbers in this assay, from the lowest: compound 3; then compounds 4, 1 and 2 (each within the scatter of the next).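

The step on the aromatic carbon meta to a bromo group and para to a large group, the first here that leaves the rest of the molecule unchanged, reads in this assay as a 1.6-fold lower number from compound 2 to compound 4 (0.20 log units; within the scatter). The earlier steps shown here replaced the whole aryl group on the amide nitrogen, so they could not show how this position alone behaves; here, going from 1 heavy atom in methyl to 5 heavy atoms in ethoxycarbonyl, with 2 hydrogen-bond acceptors added, does not move the number beyond the scatter. Nothing available bears on why this exchange leaves the read-out within the scatter.

This single step changes the size of the group and its acceptor count together, so the two cannot be told apart, and it says nothing about whether the same exchange would behave alike on another aryl group. On these data alone, whether a carboxylic acid, an amine or a longer alkyl chain on this carbon would stay within the scatter of compound 2 remains open.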